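This account rests on a few compounds, and the source may have more. Where it says the series, first, only, none or still open, it means among the compounds named here.

Compound 1 `CCCCc1cc(C(=O)O)nn1Cc1cc(Br)ccc1OCc1ccccc1`: 977 nM
Compound 2 `O=C(O)c1nn(Cc2cc(Br)ccc2OCc2ccccc2)cc1F`: 692 nM
Compound 3 `O=C(O)c1nn(Cc2cc(Br)ccc2OCc2ccccc2)cc1Br`: < 2000 nM

In a functional assay on CHO-K1 cells for antagonist activity at prostaglandin E2 receptor EP1 subtype (Homo sapiens), read by FLIPR (a lower number here means a stronger inhibitor, a higher number a weaker inhibitor), compound 1 gives 977 nM and compound 2 gives 692 nM, the two values lying within the usual scatter of each other. For compound 3 the assay reports only a limit, < 2000 nM, and not a number. The step that the limit leaves unreadable from compound 2 to compound 3 therefore cannot be sized, because the limit of < 2000 nM in this assay, at which 1 of the 3 values shown sits, hides the true value of compound 3 on the pyrazole bearing bromo.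

Compound 4 `O=C(O)c1nn(Cc2cc(Br)ccc2OCc2ccccc2)cc1Cl` is the next member of the series. It differs from compound 3 in one place: chloro in place of bromo on an aromatic carbon. Within the data shown here, no measured step shows a chloro entering for a bromo, and the only halogen exchange on this ring, a step that the limit leaves unreadable from compound 2 to compound 3, is unreadable. The nearest guide is compound 2 with fluoro at the same position, which gave 692 nM. Compound 4 is therefore expected to sit close to that figure, at 800 nM with a range from 300 nM to 2500 nM, so that the expected step that the limit leaves unreadable from compound 3 to compound 4 is not readable beyond the scatter.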

Compound 4, inhibition constant: < 2000 nM
Compound 4: only a limit was reported; the forecaster's own chance of this, stated with the estimate: 25%; the middle value is on the limit's open side.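

No step to compound 4 can be read, whether from compound 2 or from compound 3, because compound 4 too is reported only as a limit: the limit of < 2000 nM in this assay, at which 2 of the 4 values shown sit.

The compounds shown leave open where compound 3 and compound 4 truly stand in this assay, and whether bromo or chloro gives a value different from that of fluoro.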